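The compounds below may be only part of what the source reports. "The series", "measured", "known", "first", "only" and "open" are said of these compounds alone.

In a functional assay on MDA-MB-231 cells (Homo sapiens) for antiproliferative activity, read by sulforhodamine B assay, with a stated time of 48 h (on this read-out higher numbers stand for weaker inhibition of growth and lower numbers for stronger inhibition of growth), compound 1 `COc1ccc2cc(-c3cn(CCCN4C(=O)COc5ccccc54)nn3)ccc2c1` reads 5000 nM and compound 2 `COc1ccc(-c2cn(CCCN3C(=O)COc4ccccc43)nn2)cc1` reads 41500 nM on the same core, while compound 3 `CCCCCCc1cn(CCCN2C(=O)COc3ccccc32)nn1` reads 1100 nM with its hexyl group. Compound 3 thus holds the lowest of the three numbers, with compound 1 the nearest and compound 2 the furthest. Compound 4 `CCCc1cn(CCCN2C(=O)COc3ccccc32)nn1` differs from it only in the chain, which goes from hexyl to propyl hydrogen in place of propyl on a saturated chain carbon, three bonds along the chain from an aromatic carbon and reads in full as hydrogen in place of propyl on a saturated chain carbon, three bonds along the chain from an aromatic carbon.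

Among the measured compounds shown here, one measured step bears on this change, and only indirectly: a 38-fold lower number from compound 2 to compound 3 (1.58 log units; beyond the scatter) is large and shows that the group on this aromatic carbon can move the number a long way in this assay. For the measured compounds named here, no pair differing only in chain length has been measured, so that step cannot fix the size of this one. Starting from compound 3 at 1100 nM as the only chain-bearing reference, a moderate rise is expected, smaller than that large step. The expected change is a 4.1-fold higher number from compound 3 to compound 4 (0.61 log units; beyond the scatter) toward weaker inhibition of growth, probably beyond the scatter but with wide uncertainty. Compound 4 is estimated at 4500 nM (range 1500 nM to 15000 nM).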

Compound 4, concentration for 50% growth inhibition: 1100 nM
The estimate for compound 4 lay 4.1-fold (0.61 log units) above the measured number; the whole stated range lies above it.
By their numbers in this assay, from the lowest: compounds 3 and 4 (each within the scatter of the next); then compound 1; then compound 2.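

In this assay, among the compounds shown here, the step is no change at the digits printed from compound 3 to compound 4 (within the scatter), so taking the chain from hexyl to propyl leaves the reading in place, something the earlier compounds, with only hexyl as a chain on this aromatic carbon, could not show. The outer part of the hexyl chain is therefore not needed to hold the number at this level in this assay, and propyl in place of 4-methoxyphenyl gives a 38-fold lower number from compound 2 to compound 4 (1.58 log units; beyond the scatter), a large step that matches the one already seen with hexyl, so among these compounds the gap to the 4-methoxyphenyl compound holds for both chains. Nothing at hand explains why the two chains read alike.

What the compounds shown leave open is how short the chain can become before the number moves, whether a methyl or an ethyl group on this aromatic carbon would still read like propyl, and whether a chain longer than hexyl, such as octyl, would do the same. They also leave open what an amine or a carboxylic acid at the end of the chain would do to the reading.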